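A Methyl Group on the Phenoxy Ring of Compound 1

The source may report more compounds than this note shows. Statements on the series, on what has been measured and on what is new or still open speak of the compounds shown alone.

Among the compounds with values here, compound 1, `NC1=NC2(CCOCC2)N(OCCCOc2ccccc2)C(N)=N1`, is the one member of this small set with a number attached: in an assay on isolated protein for inhibition of Dihydrofolate reductase (Homo sapiens), read by spectrophotometry, using NADPH, with stated times of 5 s and 6 min (on this read-out higher numbers stand for weaker inhibition and lower numbers for stronger inhibition), compound 1 gives 86.1 nM. Two relatives, each bearing chlorine on the phenoxy ring, have no result at all. Compound 2, `NC1=NC2(CCOCC2)N(OCCCOc2ccccc2Cl)C(N)=N1`, gives "not determined" (no result reported) in this assay. Compound 3, `NC1=NC2(CCOCC2)N(OCCCOc2cccc(Cl)c2)C(N)=N1`, likewise gives "not determined" (no result reported) in this assay. Compound 1 therefore stands alone. Compound 4, `Cc1ccc(OCCCON2C(N)=NC(N)=NC23CCOCC3)cc1`, keeps the shared core and the phenoxy chain, differing from compound 1 in one place, (methyl in place of hydrogen on an aromatic carbon). Within the data shown here, with no comparison between measured compounds available, the change is expected to fall within the usual scatter, in no clear direction, giving an estimated step of a 1.1-fold lower number from compound 1 to compound 4 (0.03 log units; within the scatter) in this assay. Compound 4 is therefore expected to give about 80 nM, somewhere between 30 nM and 220 nM.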

Compound 4, half-maximal inhibitory concentration: 56.8 nM
The estimate for compound 4 lay 1.4-fold (0.15 log units) above the measured number, within the range that was stated.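

Within the data shown here, replacing phenoxy with 4-methylphenoxy gives the first readable step on this ring, a 1.5-fold lower number from compound 1 to compound 4 (0.18 log units; within the scatter) in this assay. At this place, para to a large group, one added methyl therefore leaves the number within what repeat measurements would give. Nothing measured here offers an explanation for this result.

Compound 2 and compound 3 have no numbers, so steps involving their chlorine positions cannot be read. Going by these compounds, whether an amine, a carboxylic acid or a longer chain at the methyl's place would also stay within the scatter of compound 1 remains open.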